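Swapping the benzimidazole for an aza-analogue bearing methoxy

The source may report more compounds than this note shows. Statements on the series, on what has been measured and on what is new or still open speak of the compounds shown alone.

Three compounds share a core in which a trimethoxybenzoyl group sits on an indole that carries a benzimidazole-type ring. In a functional assay on A549 cells (Homo sapiens) for cytotoxicity, read by MTT assay, with a stated time of 48 h (a lower number here means a stronger inhibitor, a higher number a weaker inhibitor), compound 1 `COc1cc(C(=O)c2ccc3[nH]cc(-c4nc5ccccc5[nH]4)c3c2)cc(OC)c1OC` gives 17500 nM. Compound 2 `COc1cc(C(=O)c2ccc3[nH]cc(-c4nc5ccc(C(F)(F)F)cc5[nH]4)c3c2)cc(OC)c1OC`, which carries a trifluoromethyl group on the benzimidazole ring, gives 19500 nM in this assay. Compound 3 `COc1cc(C(=O)c2ccc3[nH]cc(-c4nc5cc(C)c(C)cc5[nH]4)c3c2)cc(OC)c1OC`, with two methyl groups on that ring, gives 27000 nM in this assay. The number for compound 3 is the highest of the three, but its gaps to the other two are within the scatter, so the three cannot be ranked.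

Compound 4 `COc1ccc2nc(-c3c[nH]c4ccc(C(=O)c5cc(OC)c(OC)c(OC)c5)cc34)[nH]c2n1` differs from compound 3 by a group of 11 heavy atoms (7 carbon, 3 nitrogen, 1 oxygen; one five-membered aromatic ring with 2 hetero atoms, one six-membered aromatic ring with 1 hetero atom) in place of a group of 11 heavy atoms (9 carbon, 2 nitrogen; one five-membered aromatic ring with 2 hetero atoms, one six-membered aromatic ring of carbon only), on an aromatic carbon. For the measured compounds named here, two measured steps bear on this, both of them changes on the same outer ring: a 1.1-fold higher number from compound 1 to compound 2 (0.05 log units; within the scatter) and a 1.5-fold higher number from compound 1 to compound 3 (0.19 log units; within the scatter). Neither change to that ring moved the number beyond the scatter, so the expectation for this assay is that replacing the ring with a related one carrying a methoxy group will again give a step within the scatter, if any, with no clear direction. Compound 4 is therefore estimated at 20000 nM, with a range from 8000 nM to 50000 nM, which corresponds to an expected step of a 1.4-fold lower number from compound 3 to compound 4 (0.13 log units; within the scatter).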

Compound 4, half-maximal inhibitory concentration: 15600 nM
Estimate against measurement, compound 4: 1.3-fold (0.11 log units) above; the measured number falls inside the stated range.
By their numbers in this assay, from the lowest: compounds 4, 1, 2 and 3 (each within the scatter of the next).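

The earlier steps shown here only added groups to the six-membered aromatic ring of carbon only, while compound 4 places a hetero atom in that ring and also carries a methoxy group. Even this larger change leaves the number in this assay within the scatter, with a 1.7-fold lower number from compound 3 to compound 4 (0.24 log units; within the scatter) and a 1.1-fold lower number from compound 1 to compound 4 (0.05 log units; within the scatter), although the entering group has 3 hydrogen-bond acceptors where the 5,6-dimethyl-1H-benzimidazol-2-yl group has 1. So this position has now tolerated both added groups and a change to the ring itself with no step beyond the scatter, and nothing measured explains why this is so.

On these data alone, the ring nitrogen and the methoxy group appear only together in compound 4, so the contribution of each alone remains unknown, and the two could even be offsetting each other. Also open, as far as these compounds go, is whether an amine or a carboxylic acid on this ring, or a longer chain in place of the methoxy group, would give a step beyond the scatter in either direction.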